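Thiophene-carried oxadiazole in place of the aryl arm of compound 1

This account rests on a few compounds, and the source may have more. Where it says the series, first, only, none or still open, it means among the compounds named here.

Compound 1 `CC(C)(N)CC(=O)N[C@@H]1CCc2ccccc2N(Cc2ccc(-c3ccccc3-c3ncno3)cc2)C1=O` gives 30 nM in a functional assay (Pituitary gland cell) with Rattus norvegicus as the target (a lower number here means that less compound is needed, a higher number that more compound is needed for the effect), the lowest number among the three measured compounds. Compound 2 `CC(C)(N)CC(=O)N[C@@H]1CCc2ccccc2N(Cc2ccc(-c3sccc3-c3nn[nH]n3)cc2)C1=O` gives 140 nM and compound 3 `CC(C)(N)CC(=O)N[C@@H]1CCc2ccccc2N(Cc2ccc(-c3cscc3-c3nn[nH]n3)cc2)C1=O` gives 150 nM; these two lie within the scatter of each other a 1.1-fold higher number from compound 2 to compound 3 (0.03 log units; within the scatter). Compound 4 `Cc1nnc(-c2cscc2-c2ccc(CN3C(=O)[C@H](NC(=O)CC(C)(C)N)CCc4ccccc43)cc2)o1` differs from compound 1 by 4-(5-methyl-1,3,4-oxadiazol-2-yl)thiophen-3-yl in place of 2-(1,2,4-oxadiazol-5-yl)phenyl on an aromatic carbon. The measured steps that bear on this are a 4.7-fold higher number from compound 1 to compound 2 (0.67 log units; beyond the scatter) and a 5.0-fold higher number from compound 1 to compound 3 (0.70 log units; beyond the scatter); both exchange the same leaving group for a thiophenyl carrying a 2H-tetrazol-5-yl, and both raise the number modestly. Compound 4 retains an oxadiazole on the entering thiophenyl, so a smaller rise is expected, an estimated step of a 2.7-fold higher number from compound 1 to compound 4 (0.43 log units; beyond the scatter) in this assay. Compound 4 is accordingly estimated at 80 nM, with a range from 30 nM to 250 nM.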

Compound 4, half-maximal effective concentration: 125 nM
The estimate for compound 4 lay 1.6-fold (0.19 log units) below the measured number, and the stated range covers the measured number.
By their numbers in this assay, from the lowest: compound 1; then compounds 4, 2 and 3 (each within the scatter of the next).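

In this assay, an oxadiazole on the thiophene does not keep the number near that of compound 1: a 4.2-fold higher number from compound 1 to compound 4 (0.62 log units; beyond the scatter). Exchanging 2H-tetrazol-5-yl for 5-methyl-1,3,4-oxadiazol-2-yl stays within the scatter, with a 1.2-fold lower number from compound 3 to compound 4 (0.08 log units; within the scatter) and a 1.1-fold lower number from compound 2 to compound 4 (0.05 log units; within the scatter), so among these thiophenes the azole makes no readable difference. Nothing available explains the rise from compound 1.

Because compound 4 changes both rings at once, the thiophene's share of the rise remains unseparated. Also open, from the compounds shown here alone, is whether a carboxylic acid or an amine on the thiophene would fall with these three.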